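A few compounds are considered here, and "the series" means these few. Any claim that something is new, unique, unknown or untested is made for them only; others in the source may bear on it.

Compound 1 `S=c1n(-c2ccccc2)c(=S)n2n1CCCC2` gives 2040 nM
Compound 2 `S=c1s/c(=N\c2ccc(Br)cc2)n2n1CCCC2` gives 550 nM
Compound 3 `S=c1n(-c2ccc(Br)cc2)c(=S)n2n1CCCC2` gives 46.8 nM

These three values come from a functional assay on the whole organism with Scenedesmus acutus as the target, with a stated time of 20 h; on this read-out higher numbers stand for weaker inhibition and lower numbers for stronger inhibition. Compound 2 at 550 nM stands second highest of the three, with compound 1 above it and compound 3 below it, both beyond the scatter.

Compound 4 (`S=c1s/c(=N\c2ccccc2)n2n1CCCC2`) has not yet been measured. It differs from compound 2 by hydrogen in place of bromo on an aromatic carbon, para to a large group (hydrogen in place of bromo on an aromatic carbon). Within the data shown here, one measured step bears on this change. It is the reverse exchange, bromo in place of hydrogen, on the core of compound 1 (a 44-fold lower number from compound 1 to compound 3 (1.64 log units; beyond the scatter)), and it was large. Read backwards, that step points to a higher number on losing the bromo. Among the measured compounds shown here, it is only a single pair, however, and its core differs from that of compound 2, so it may not carry over in full. A large step to a higher number is therefore expected in this assay, though somewhat smaller than the one seen on the core of compound 1. The estimated step is an 11-fold higher number from compound 2 to compound 4 (1.04 log units; beyond the scatter) in size. For compound 4 the estimated value is 6000 nM with an expected range from 1800 nM to 20000 nM as a result.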

Compound 4, half-maximal inhibitory concentration: 4370 nM
For compound 4 the middle estimate is 1.4-fold (0.14 log units) above the measured one; the range from low to high includes it.
By their numbers in this assay, from the lowest: compound 3; then compound 2; then compound 1; then compound 4.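

In this assay, the exchange between bromo and hydrogen on an aromatic carbon, para to a large group, has now been seen on a second core: hydrogen in place of bromo gives a 7.9-fold higher number from compound 2 to compound 4 (0.90 log units; beyond the scatter). The direction therefore matches that on the core of compound 1, and neither of the two available pairs goes against it, although two pairs are a narrow basis for any pattern. What the earlier compounds could not show is that the size of the step does not carry over unchanged from one core to the other, as the two steps differ by more than the usual scatter: the same change on two cores in this assay, a 44-fold lower number (1.64 log units; beyond the scatter) from compound 1 to compound 3 and a 7.9-fold lower number (0.90 log units; beyond the scatter) from compound 4 to compound 2, 5.5-fold (0.74 log units) apart, beyond the scatter of two such steps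

The compounds shown carry only hydrogen or bromo at this place, so it remains open whether chloro, fluoro, methyl or methoxy would follow the same direction on either core, and how large any such step would be. On these data alone, it also remains open whether the difference between the two cores would persist with a group such as a nitrile, or with bromo on another carbon of the aromatic ring.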